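The source may report more compounds than this note shows. Statements on the series, on what has been measured and on what is new or still open speak of the compounds shown alone.

Working notes on the series, read in a functional assay on MCF7 cells (Homo sapiens) for cytotoxicity, read by MTT assay, with a stated time of 72 h; a lower number here means a stronger inhibitor, a higher number a weaker inhibitor. Within the data shown here, compound 1 `Nc1cc2nc(-c3ccccc3)nn(-c3ccccc3)c-2cc1=O` gives 950 nM, the only true number so far. Compound 2 `CCN(CC)c1cc2nc(-c3ccccc3)nn(-c3ccccc3)c-2cc1=O` stands at > 5000 nM, which is a limit and not a number. Compound 3 `CC(=O)Nc1cc2nc(-c3ccccc3)nn(-c3ccccc3)c-2cc1=O` stands at > 5000 nM, which is also a limit. The two compounds together make up (the limit of > 5000 nM in this assay, at which 2 of the 3 values shown sit).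

The change under review leads to compound 4 `CCOc1cc2nc(-c3ccccc3)nn(-c3ccccc3)c-2cc1=O`: ethoxy in place of diethylamino on an aromatic carbon. Ethoxy replaces diethylamino on the same aromatic carbon of the shared core.

Among the measured compounds shown here, two measured steps bear on this, and both end at the limit. Diethylamino in place of amino gives an at least 5.2-fold higher number from compound 1 to compound 2 (0.72 log units; beyond the scatter). Acetyl in place of hydrogen on the nitrogen gives an at least 5.2-fold higher number from compound 1 to compound 3 (0.72 log units; beyond the scatter). On these data alone, each is beyond the scatter, but its full size stays open. The third step, a step that the two limits leave unreadable from compound 2 to compound 3, adds nothing. For the measured compounds named here, no measured compound carries ethoxy, so the reading across is loose.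

Going by the values given here, with compound 1 at 950 nM the only true number, only a modest move towards a lower number is expected. A result at the limit remains quite possible. The expected step is an at least 1.4-fold lower number from compound 2 to compound 4 (0.15 log units; that floor lies within the scatter). For compound 4 the estimated value is 3500 nM, with an expected range of 1000 nM to 10000 nM.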

Compound 4, half-maximal inhibitory concentration: > 5000 nM
Compound 4: no number, only a limit (the forecaster's own chance of this, stated with the estimate: 45%); at least 1.4-fold (0.15 log units) between middle value and limit.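

In this assay, ethoxy in place of amino gives an at least 5.2-fold higher number from compound 1 to compound 4 (0.72 log units; beyond the scatter), so a third replacement of the amino group on this aromatic carbon, now one joined through oxygen, also moves beyond the scatter; among compounds 1 to 4, only compound 1, with its amino group, gives a true number, and none of the others goes against this. Compound 4 stands at a limit and not a number, so going from the 5 heavy atoms of diethylamino to the 3 of ethoxy does not by itself bring a true number back. The steps among compounds 2, 3 and 4 cannot be read, as each joins two limits, and the series now rests largely on a single ceiling: the limit of > 5000 nM in this assay, at which 3 of the 4 values shown sit.

On these data alone, how far compounds 2, 3 and 4 each lie past that limit stays open, so diethylamino, acetamido and ethoxy cannot be ranked against one another. Also open, as far as these compounds go, is whether a methylamino group, a hydroxyl group or a methoxy group on this aromatic carbon would give a true number, and how such a number would compare with that of compound 1.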